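The source may report more compounds than this note shows. Statements on the series, on what has been measured and on what is new or still open speak of the compounds shown alone.

Of the compounds shown here, two have been measured in a functional assay on Hs-578T cells (Homo sapiens) for inhibition, read by sulforhodamine B assay, with a stated time of 48 h; on this read-out lower numbers stand for stronger inhibition of growth and higher numbers for weaker inhibition of growth. Compound 1 `O=C(Nc1cccc(-n2cc(-c3ccncc3)c(-c3ccc(Cl)c(O)c3)n2)c1)Nc1ccc(Cl)c(Cl)c1` carries a urea link to a dichlorophenyl group and gives 3150 nM in this assay. Compound 2 `COc1cc(-c2nn(-c3cccc(NC(=O)c4ccc(Cl)c(C(F)(F)F)c4)c3)cc2-c2ccncc2)ccc1Cl`, which instead carries an amide to a 4-chloro-3-(trifluoromethyl)phenyl group, gives only a limit: in this assay compound 2 reaches > 32500 nM, which is not a number but the edge of what the assay can report. The two values here show that compound 2 sits at the limit of > 32500 nM in this assay, at which 1 of the 2 values shown sits, while compound 1 gives a genuine number.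

The next compound follows from compound 2 by a single change. Compound 3 `COc1cc(-c2nn(-c3cccc(NC(=O)c4ccccc4)c3)cc2-c2ccncc2)ccc1Cl` differs from compound 2 in that (phenyl in place of 4-chloro-3-(trifluoromethyl)phenyl on a carbonyl carbon). Two substituents are thus dropped from the amide-bearing ring, leaving a bare phenyl.

Since compound 2 already gives only a limit, no step beyond the scatter is expected from compound 2 to compound 3, so the expected step that the limit leaves unreadable from compound 2 to compound 3 is essentially flat. Compound 3 is therefore expected to give about 40000 nM in this assay, with a likely range from 12000 nM to 120000 nM, and most probably again only a limit.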

Compound 3, concentration for total growth inhibition: > 100000 nM
Compound 3 ended at the assay's limit; the forecaster's own chance of this, stated with the estimate: 70%; at least 2.5-fold (0.39 log units) between middle value and limit.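

For the compounds shown here, compound 2 and compound 3 both stop at limits of this assay rather than at real numbers, and no step between them can be read. The compounds shown leave open where their true values lie, and whether phenyl in place of 4-chloro-3-(trifluoromethyl)phenyl changes growth inhibition at all.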